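Sec-butyl in Place of Hydroxymethyl on the Chloropurine Series

This account rests on a few compounds, and the source may have more. Where it says the series, first, only, none or still open, it means among the compounds named here.

Measured so far in a functional assay on the whole organism (Tail, strain ICR) with Mus musculus as the target, in the tail flick test, with a stated time of 120 min, at a dose of 25 umol/kg by the oral route; on this read-out lower numbers stand for a weaker effect and higher numbers for a stronger effect at the one dose given:
Compound 1 `O=C(CN(c1nc(Cl)nc2[nH]cnc12)C1CC1)N[C@@H](CO)C(=O)OCc1ccccc1` gives 34.5%
Compound 2 `O=C(CN(c1nc(Cl)nc2[nH]cnc12)C1CC1)N[C@@H](CO)C(=O)O` gives 39%
Compound 3 `CC[C@H](C)[C@H](NC(=O)CN(c1ncnc2c1ncn2C1CCCCO1)C1CC1)C(=O)OCc1ccccc1` gives 20.4%

Among these three, compound 1 stands second highest. Its nearest neighbour is compound 2: the step of a number 4.5 percentage points higher from compound 1 to compound 2 (within the scatter) is within the scatter, so the two cannot be told apart. Among the measured compounds shown here, compound 3 lies furthest away, with a number lower than that of compound 1 by more than the scatter, but no single-change step connects it to compound 1, since it differs in the core as well as in the side chain.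

Compound 4 `CC[C@H](C)[C@H](NC(=O)CN(c1nc(Cl)nc2[nH]cnc12)C1CC1)C(=O)OCc1ccccc1` is the next candidate. It differs from compound 1 in one place: sec-butyl in place of hydroxymethyl on a saturated chain carbon bound to an amide-type nitrogen and a carbonyl carbon. For the measured compounds named here, no measured step touches this place; the only step on record, the benzyl-to-hydrogen exchange on the ester, changed nothing beyond the scatter. Compound 3 carries the same sec-butyl and benzyl ester as compound 4 and gave the lowest of the three numbers, but its different core leaves this only a hint.

The expectation for compound 4 is therefore a modest step downward, a number 7.5 percentage points lower from compound 1 to compound 4 (within the scatter), with little confidence that it will clear the scatter. Compound 4 is estimated to give 27%, within a range from 12% to 44%.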

Compound 4, a percentage reported as activity, at one dose (the size of the read-out at that dose, not a potency): 22%
For compound 4 the middle estimate is 5 percentage points above the measured one; the measured number falls inside the stated range.
By their numbers in this assay, from the lowest: compounds 3 and 4 (each within the scatter of the next); then compounds 1 and 2 (each within the scatter of the next).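

Among the compounds shown here, exchanging hydroxymethyl for sec-butyl gives a number 12.5 percentage points lower from compound 1 to compound 4 (beyond the scatter) in this assay, so this is the first single change whose effect can be told from noise, whereas exchanging benzyl for hydrogen on the ester gave only a number 4.5 percentage points higher from compound 1 to compound 2 (within the scatter). The side chain on this saturated chain carbon therefore matters for the read-out in this pair: the group that leaves carries a hydrogen-bond donor and a hydrogen-bond acceptor, while the group that enters carries neither and has more heavy atoms, and one exchange cannot separate these differences. Nothing in the available data accounts for the step.

The compounds shown leave open how the read-out would respond to other groups at this place, such as methyl, a longer chain ending in hydroxyl, or a chain ending in an amine, any of which could help to separate the loss of the hydroxyl from the gain in chain size. They also leave open whether this step would keep its size at other doses or other times after dosing, since each compound is read at one dose and one time.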